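Replacing the sulfur substituent of compound 1

The source may hold more compounds than are shown below. What is called first, only, known or untested is meant among the compounds shown, and "the series" means these compounds.

In a functional assay on DU-145 cells (Homo sapiens) for inhibition, read by trypan blue exclusion, with a stated time of 96 h (on this read-out higher numbers stand for weaker inhibition of growth and lower numbers for stronger inhibition of growth), compound 1 (`O=C(/C(=C\c1ccc(O)c([N+](=O)[O-])c1)SCc1ccc(Br)cc1)c1ccc(Br)cc1`) gives 10000 nM. Compound 2 (`O=C(/C(=C\c1ccc(O)c(C(=O)O)c1)SCc1ccc(Br)cc1)c1ccc(Br)cc1`) gives 10000 nM, and compound 3 (`O=C(/C(=C\c1cc(Cl)c(O)c(Cl)c1)SCc1ccc(Br)cc1)c1ccc(Br)cc1`) gives 10000 nM, so compound 1 stands level with both. Compound 4 (`O=C(/C(=C\c1ccc(O)c([N+](=O)[O-])c1)Sc1ccccc1Br)c1ccc(Br)cc1`) keeps the rest of compound 1 but has 2-bromophenyl in place of 4-bromobenzyl on a sulfur.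

Three measured steps are available: no change at the digits printed from compound 1 to compound 2 (within the scatter), no change at the digits printed from compound 1 to compound 3 (within the scatter) and no change at the digits printed from compound 2 to compound 3 (within the scatter). All of them lie within the scatter, but none touches the group on sulfur, so they bear on the new change only indirectly. Going by the values given here, no measurement yet isolates that group. With compound 1 at 10000 nM as the starting point, no step beyond the scatter is expected in this assay, and neither direction is favoured. The expected step is a 1.3-fold lower number from compound 1 to compound 4 (0.10 log units; within the scatter). Compound 4 is estimated at 8000 nM, with an expected range from 2500 nM to 16000 nM.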

Compound 4, concentration for 50% growth inhibition: 10000 nM
Compound 4: the middle estimate sits 1.3-fold (0.10 log units) below what was measured; measured number inside the range.
By their numbers in this assay, from the lowest: compounds 1, 2, 3 and 4 (each within the scatter of the next).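

With 2-bromophenyl in place of 4-bromobenzyl on a sulfur, this assay shows no change at the digits printed from compound 1 to compound 4 (within the scatter). Going by these compounds alone, this is the first measured change to the group on sulfur, as the earlier steps all concerned the substituted phenyl on the double-bonded chain carbon. Here, the bromine's printed place on the ring and the loss of the benzyl form change together, so this single step cannot separate the two, and no information is available on why the number stays level.

The compounds shown leave open whether an amine, a carboxylic acid or a longer chain on this sulfur would move the number beyond the scatter. They also leave open whether 2-bromophenyl on a sulfur would read the same alongside the 3-carboxy-4-hydroxyphenyl of compound 2 or the 3,5-dichloro-4-hydroxyphenyl of compound 3.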